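A Second Methyl on the Piperazine Ring

The compounds below may be only part of what the source reports. "The series", "measured", "known", "first", "only" and "open" are said of these compounds alone.

Three compounds share one core and are compared in an assay on RKO cells for inhibition of ubiquitin carboxyl-terminal hydrolase 7 (Homo sapiens), read by a luciferase reporter, with a stated time of 18 h; a lower number here means that less compound is needed, a higher number that more compound is needed for the effect. Compound 1 has the structure `Cc1cc(Cl)cc(-c2ccnc3cc(CN4C(=O)CCC4=O)sc23)c1CN1CCNC[C@@H]1C`; in this assay compound 1 gives 280 nM. Compound 2, with the structure `Cc1cc(Cl)cc(-c2ccnc3cc(CN4C(=O)C5CC5C4=O)sc23)c1C[C@H]1OCCN[C@@H]1C`, gives 210 nM in this assay, and compound 3, with the structure `Cc1cc(Cl)cc(-c2ccnc3cc(CN4C(=O)C5C(C4=O)C5(C)C)sc23)c1OC1CCCNC1`, gives 250 nM. The three numbers fall close together, and the gaps between compound 1 and each of the other two are within the scatter of repeated measurements, so none of the three can be set apart from the others on these data.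

Compound 4 has the structure `Cc1cc(Cl)cc(-c2ccnc3cc(CN4C(=O)CCC4=O)sc23)c1CN1[C@@H](C)CNC[C@@H]1C`. It differs from compound 1 in one place: methyl in place of hydrogen on a saturated ring carbon. Going by the values given here, no measured pair shows what this kind of change does here, so the expectation rests on the narrow spread of the three measured values and on the small size of the added group. The step from compound 1 to compound 4 is expected to be about a 1.1-fold higher number from compound 1 to compound 4 (0.03 log units; within the scatter), that is, not beyond the scatter in either direction. For compound 4 the estimated value in this assay is 300 nM, with a likely range from 120 nM to 750 nM.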

Compound 4, half-maximal effective concentration: 60 nM
Estimate against measurement, compound 4: 5.0-fold (0.70 log units) above; measured number outside the range, below it.
By their numbers in this assay, from the lowest: compound 4; then compounds 2, 3 and 1 (each within the scatter of the next).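

Replacing 2-methylpiperazin-1-yl with 2,6-dimethylpiperazin-1-yl gives a 4.7-fold lower number from compound 1 to compound 4 (0.67 log units; beyond the scatter) in this assay. Going by these compounds alone, this is the first change in one place that can be read here, and it shows that a single added methyl on this saturated ring carbon, next to the ring nitrogen and the ring atom bearing the large group, can move the number beyond the usual scatter. No measurement shown here explains why this small addition has such an effect.

This single pair cannot show whether the gain depends on the methyl itself or would also appear with an ethyl group or a fluorine atom at the same carbon. The pair also leaves open whether the opposite arrangement of the new methyl on the ring would give a similar number.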